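A few compounds are considered here, and "the series" means these few. Any claim that something is new, unique, unknown or untested is made for them only; others in the source may bear on it.

Measured compounds:
compound 1, `CCOC(=O)Cc1nc(N)n(C(=O)c2ccc(Cl)cc2)n1`: 62.8%
compound 2, `CCOC(=O)Cc1nc(N)n(C(=O)c2ccc(Br)cc2)n1`: 64.1%

In a functional assay on the whole organism (strain albino) for inhibition, with Rattus norvegicus as the target, read by paw edema, with stated times of 30 min and 3 h, at a dose of 5 mg/kg by the oral route (on this read-out higher numbers stand for more inhibition at the one dose given (going by the name of the read-out) and lower numbers for less inhibition), compound 2 gives 64.1% and compound 1 gives 62.8%; the two stand level, the gap between them within the scatter. Compound 3, `CCOC(=O)Cc1nc(N)n(C(=O)c2ccc(OC)cc2)n1`, differs from compound 2 by methoxy in place of bromo on an aromatic carbon. For the measured compounds named here, the only measured step, a number 1.3 percentage points higher from compound 1 to compound 2 (within the scatter), exchanged one halogen for another and stayed within the scatter; nothing measured bears directly on a methoxy entering. Compound 3 is therefore expected to remain near compound 2, with a wider allowance for uncertainty, a step of a number 6.1 percentage points lower from compound 2 to compound 3 (within the scatter). The estimate for compound 3 is 58%, from 42% to 72%.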

Compound 3, a percentage reported as inhibition, in the whole organism at one dose (the size of the read-out at that dose, not a potency): 60%
Compound 3: middle estimate off by 2 percentage points, on the low side, within the range that was stated.
By their numbers in this assay, from the lowest: compounds 3, 1 and 2 (each within the scatter of the next).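

Methoxy in place of bromo on the aromatic carbon para to a large group is a number 4.1 percentage points lower from compound 2 to compound 3 (within the scatter) and methoxy in place of chloro is a number 2.8 percentage points lower from compound 1 to compound 3 (within the scatter) in this assay. This position, so far seen carrying only halogens, thus also takes a group of two heavy atoms with a hydrogen-bond acceptor, and the read-out stays level with both halogen compounds. No evidence is at hand that explains this level reading. Going by these compounds, what an amine, a carboxylic acid or a longer chain such as butoxy would do at this position remains open.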